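A few compounds are considered here, and "the series" means these few. Any claim that something is new, unique, unknown or untested is made for them only; others in the source may bear on it.

In a functional assay on HCT-116 cells (Homo sapiens) for cytotoxicity, read by MTT assay, with a stated time of 48 h, in the presence of a further agent that is not named here (a lower number here means that less compound is needed, a higher number that more compound is needed for the effect), compound 1 `Cn1ncc2c(-c3ccc(F)cc3)cc(NNC(=O)Nc3cc(Cl)nc(OCCF)c3)nc21` gives 37200 nM and compound 2 `Cn1ncc2c(-c3ccc(F)cc3)cc(NNC(=O)Nc3cc(Cl)nc(Cl)c3)nc21` gives 8210 nM, the lower of the two numbers. Compound 3 `Cn1ncc2c(-c3ccc(F)cc3)cc(NNC(=O)Nc3cc(F)cc(F)c3)nc21` differs from compound 2 by 3,5-difluorophenyl in place of 2,6-dichloropyridin-4-yl on an amide-type nitrogen, with 3,5-difluorophenyl in place of 2,6-dichloropyridin-4-yl on an amide-type nitrogen. Among the measured compounds shown here, the only measured step, a 4.5-fold lower number from compound 1 to compound 2 (0.66 log units; beyond the scatter), bears on this indirectly, since it swaps 2-fluoroethoxy for chloro on an aromatic carbon. For the measured compounds named here, no measured step replaces the whole group, so no clear direction is expected, and a shift of similarly modest size remains possible. The expected change is a 1.2-fold higher number from compound 2 to compound 3 (0.09 log units; within the scatter). Compound 3 is estimated at 10000 nM, with an expected range of 3000 nM to 35000 nM.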

Compound 3, half-maximal effective concentration: 46200 nM
Compound 3: middle estimate off by 4.6-fold (0.66 log units), on the low side; the whole stated range lies below it.
By their numbers in this assay, from the lowest: compound 2; then compounds 1 and 3 (each within the scatter of the next).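

In this assay, the amide-type nitrogen proves sensitive to its aryl group: with 3,5-difluorophenyl in place of 2,6-dichloropyridin-4-yl, there is a 5.6-fold higher number from compound 2 to compound 3 (0.75 log units; beyond the scatter), although the heavy-atom count stays the same. Against the 2-chloro-6-(2-fluoroethoxy)pyridin-4-yl group, the same 3,5-difluorophenyl gives a 1.2-fold higher number from compound 1 to compound 3 (0.09 log units; within the scatter), so among these three compounds only compound 2 stands apart. No measurement here explains this difference.

The ring nitrogen and the chlorines change together, so the compounds shown leave open which of them matters. A 3,5-dichlorophenyl group on this nitrogen would separate the two.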